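A few compounds are considered here, and "the series" means these few. Any claim that something is new, unique, unknown or untested is made for them only; others in the source may bear on it.

Measured so far in a physicochemical assay for lipophilicity, using the shake flask method, at pH 7.4; on this read-out lower numbers stand for lower lipophilicity and higher numbers for higher lipophilicity:
- compound 1 `COc1ccc(S(N)(=O)=O)cc1C(=O)Nc1cccc(-c2nncn2C(C)C)n1`: 1.2
- compound 2 `CC(C)n1cnnc1-c1cccc(NC(=O)c2cccc(-c3ncc[nH]3)c2)n1`: 2.4

Compound 1 stands at the low end of this small set. In this assay compound 1 gives 1.2, the lower of the two numbers, and compound 2 gives 2.4, a gap beyond the usual scatter. These two compounds differ in more than one place, so their gap gives no measure of any single change.

The next compound is compound 3 `COc1cc(C)c(S(N)(=O)=O)cc1C(=O)Nc1cccc(-c2nncn2C(C)C)n1`. Relative to compound 1, it has methyl in place of hydrogen on an aromatic carbon, ortho to a sulfamoyl group, meta to a methoxy group and para to a large group: methyl in place of hydrogen on an aromatic carbon. The rest of the structure is unchanged.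

Within the data shown here, no measured pair in the set isolates this change, so the expectation rests on the structural change alone. A small upward move in this assay is expected, and the estimated step is a number 0.40 log units higher from compound 1 to compound 3 (beyond the scatter). For compound 3 the estimated value is 1.6, with an expected range from 1.25 to 1.95.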

Compound 3, distribution coefficient: 1.6
Estimate against measurement, compound 3: no gap at the digits printed; measured number inside the range.
By their numbers in this assay, from the lowest: compound 1; then compound 3; then compound 2.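

Methyl in place of hydrogen on an aromatic carbon, ortho to a sulfamoyl group, meta to a methoxy group and para to a large group, gives the first step in this assay that can be read for a single change: a number 0.40 log units higher from compound 1 to compound 3 (beyond the scatter) with the rest of the structure held constant. This places a measured size on one added carbon at this position of the six-membered aromatic ring, which the gap between compound 1 and compound 2 could not do, as those two differ in more than one place. Nothing at hand bears on why the step has this size.

Still open, on these data alone, is whether an ethyl group, a chlorine atom or an amine on this same carbon would move the read-out in the same direction and by a similar amount, and whether methyl elsewhere on the ring gives a comparable step. One pair also leaves open whether this step holds when the methoxy group gives way to a hydroxyl group or a longer ether chain.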